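From furan-3-yl to ethynyl on a weak compound

The source may report more compounds than this note shows. Statements on the series, on what has been measured and on what is new or still open speak of the compounds shown alone.

Measured in a functional assay on HCT-116 cells (Homo sapiens), read by MTT assay, with a stated time of 72 h; a lower number here means a stronger inhibitor, a higher number a weaker inhibitor:
- compound 1 `C#Cc1cn([C@@H]2O[C@H](CO)[C@@H](O)[C@H]2O)c2ncnc(OC)c12`: 4060 nM
- compound 2 `CSc1ncnc2c1c(-c1ccoc1)cn2[C@@H]1O[C@H](CO)[C@@H](O)[C@H]1O`: 40 nM
- compound 3 `CN(C)c1ncnc2c1c(-c1ccoc1)cn2[C@@H]1O[C@H](CO)[C@@H](O)[C@H]1O`: > 20000 nM (a limit, not a number)

Compound 3 gives no number and stands only at the limit of > 20000 nM in this assay, at which 1 of the 3 values shown sits. Compound 4 `C#Cc1cn([C@@H]2O[C@H](CO)[C@@H](O)[C@H]2O)c2ncnc(N(C)C)c12` keeps the dimethylamino group of compound 3 and changes one place: ethynyl in place of furan-3-yl on an aromatic carbon. Among the measured compounds shown here, no measured step covers this swap directly. The nearest evidence is an at least 500-fold higher number from compound 2 to compound 3 (2.69 log units; beyond the scatter), a large step that brought in the same dimethylamino group that compound 4 retains. The ethynyl group appears only in compound 1, which gives 4060 nM, a much higher number than that of compound 2, 40 nM. Neither group has therefore been seen with a low number. Since compound 3 offers only a limit, the size of the step cannot be fixed, and no clear gain is expected in this assay. The expected step is an at least 1.1-fold lower number from compound 3 to compound 4 (0.04 log units; that floor lies within the scatter). For compound 4 the estimated value is 18000 nM, with an expected range from 5000 nM to 60000 nM.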

Compound 4, half-maximal inhibitory concentration: 180 nM
Compound 4: the middle estimate sits 100-fold (2.00 log units) above what was measured, outside the stated range (below it).
By their numbers in this assay, from the lowest: compound 2; then compound 4; then compound 1. At a limit, above all of these: compound 3.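

In this assay, the group on this aromatic carbon turns out to matter greatly even with dimethylamino kept on the core: ethynyl in place of furan-3-yl gives an at least 110-fold lower number from compound 3 to compound 4 (2.04 log units; beyond the scatter). Dimethylamino therefore does not always go with a high number, for with ethynyl held fixed, dimethylamino in place of methoxy gives a 23-fold lower number from compound 1 to compound 4 (1.35 log units; beyond the scatter), whereas with furan-3-yl held fixed, dimethylamino in place of methylsulfanyl gave an at least 500-fold higher number from compound 2 to compound 3 (2.69 log units; beyond the scatter). The size of the ethynyl step stays open-ended, as compound 3 gives a limit and not a number: the limit of > 20000 nM in this assay, at which 1 of the 4 values shown sits.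

Still open, as far as these compounds go, is how ethynyl behaves with methylsulfanyl on the core, the pairing that would test these two groups together. Also open, from the compounds shown here alone, is whether a nitrile or a longer alkyne such as propynyl on this carbon would give a similarly low number.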